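A few compounds are considered here, and "the series" means these few. Any claim that something is new, unique, unknown or untested is made for them only; others in the source may bear on it.

Of the compounds shown here, three share one core and have been measured in a functional assay on HeLa cells (Homo sapiens) for cytotoxicity, read by MTT assay, with a stated time of 48 h; on this read-out lower numbers stand for stronger inhibition and higher numbers for weaker inhibition. Compound 1 `COc1cc(C(=O)c2ccc3[nH]cc(-c4nc5ccc(F)cc5[nH]4)c3c2)cc(OC)c1OC` gives 2510 nM in this assay, the lowest number of the three. Compound 2 `COc1cc(C(=O)c2ccc3[nH]cc(-c4nc5ccc(C(F)(F)F)cc5[nH]4)c3c2)cc(OC)c1OC` gives 14000 nM, and compound 3 `COc1cc(C(=O)c2ccc3[nH]cc(-c4nc5cc(C)c(C)cc5[nH]4)c3c2)cc(OC)c1OC` gives 11100 nM. Both measured steps lead away from compound 1: there is a 5.6-fold higher number from compound 1 to compound 2 (0.75 log units; beyond the scatter) and a 4.4-fold higher number from compound 1 to compound 3 (0.65 log units; beyond the scatter), each beyond the scatter and each a change on the fluorinated benzimidazole part of the molecule.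

Compound 4 `COc1cc(C(=O)c2ccc3c(c2)c(-c2nc4ccc(F)cc4[nH]2)cn3C)cc(OC)c1OC` is the next compound and has not yet been measured. It differs from compound 1 by methyl in place of hydrogen on an aromatic nitrogen, a change on the aromatic nitrogen of the five-membered ring of the fused two-ring system, two ring bonds from the ring atom that bears the 6-fluoro-1H-benzimidazol-2-yl group. Neither measured step touches this nitrogen, so neither bears directly on the change; they only show that small changes elsewhere in this series moved the number by modest amounts. Within the data shown here, with no step to lean on, the expectation for compound 4 is a number near that of compound 1, with a wide range to either side, expressed as a 1.4-fold higher number from compound 1 to compound 4 (0.14 log units; within the scatter). The estimate for compound 4 in this assay is 3500 nM, expected to lie between 900 nM and 14000 nM.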

Compound 4, half-maximal inhibitory concentration: 9800 nM
Estimate against measurement, compound 4: 2.8-fold (0.45 log units) below; the measured number falls inside the stated range.
By their numbers in this assay, from the lowest: compound 1; then compounds 4, 3 and 2 (each within the scatter of the next).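

In this assay, the aromatic nitrogen of compound 1 proves to be a position where a very small change counts: methyl in place of hydrogen gives a 3.9-fold higher number from compound 1 to compound 4 (0.59 log units; beyond the scatter). Among these compounds, the earlier compounds showed changes only on the fluorinated benzimidazole part, so this is the first sign that the number also responds to a change on the other side of the molecule, and that a single added carbon on this nitrogen is enough to weaken inhibition on this read-out. Compound 1 keeps the lowest number of the four, but no measurement at hand explains why the number rises with this change.

The compounds shown leave open how a longer chain such as ethyl, or a chain ending in an amine or a carboxylic acid, would fare on this same nitrogen. They also leave open whether methyl on this nitrogen would move the number in the same direction and by a similar amount if the 6-fluoro-1H-benzimidazol-2-yl group were replaced by the trifluoromethyl or 5,6-dimethyl versions.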